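Chloropurines bearing a chloromethylbenzyl group: growth inhibition notes

This account rests on a few compounds, and the source may have more. Where it says the series, first, only, none or still open, it means among the compounds named here.

Compounds 2 and 3 share one core, compound 2 being `ClCc1cccc(Cn2cnc3c(Cl)ncnc32)c1` and compound 3 being `ClCc1cccc(Cn2cnc3c(Cl)nc(Cl)nc32)c1`. Compound 1, `ClCc1cccc(Cn2cnc3ncnc(Cl)c32)c1`, is built from the same atoms as compound 2 joined differently; the difference between the two cores is not broken down here. Compound 4, `ClCc1cccc(Cn2cnc3nc(Cl)nc(Cl)c32)c1`, has not been measured.

In a functional assay on HOP-92 cells (Homo sapiens) for cytotoxicity, read by sulforhodamine B assay, with a stated time of 48 h (on this read-out lower numbers stand for stronger inhibition of growth and higher numbers for weaker inhibition of growth), compound 2 gives 6160 nM and compound 3 gives 3630 nM. The structural change between them is chloro in place of hydrogen on an aromatic carbon and it made a step of a 1.7-fold lower number from compound 2 to compound 3 (0.23 log units; within the scatter). For compound 1 the result in this assay is "not determined" (no result reported), so compound 1 offers no anchor of its own.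

The same change, (chloro in place of hydrogen on an aromatic carbon), links compound 1 to compound 4; the place of the entering chloro is described in identical terms in both pairs. Among the measured compounds shown here, no step from compound 1 to compound 4 can be stated in this assay while compound 1 stands at "not determined" (no result reported). Were compound 1 measured, the step to compound 4 would be expected to be of about the size seen from compound 2 to compound 3, a change within the scatter.

Compound 4 is expected to give 4000 nM in this assay, with a likely range from 1500 nM to 12000 nM. This rests on compound 3 at 3630 nM, the dichloro compound on the other core, and on the two dichloro cores differing only as compound 1 and compound 2 do, a difference not broken down here, which widens the range.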

Compound 4, concentration for total growth inhibition: 2750 nM
For compound 4 the middle estimate is 1.5-fold (0.16 log units) above the measured one, within the range that was stated.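

In this assay, among the compounds shown here, compound 4 gives 2750 nM while compound 1 stands at "not determined" (no result reported), and no step from compound 1 to compound 4 can be read. The compounds shown leave open what the chloro entering between two ring nitrogen atoms does on the core of compound 1, and how the two cores compare. No supporting evidence bears on this result.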